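Replacing the hydroxyethyl amine with a carboxy-bearing chain

The source may report more compounds than this note shows. Statements on the series, on what has been measured and on what is new or still open speak of the compounds shown alone.

Compound 1, `COc1ccc(/C=C\c2cc(OC)c(OC)c(OC)c2)cc1OCc1ccc(CN2CCCCC2C(=O)O)cc1`, gives 5400 nM in a functional assay on MC-38 cells (Mus musculus) for antiproliferative activity, read by CCK-8 assay, with a stated time of 48 h; a lower number here means a stronger inhibitor, a higher number a weaker inhibitor.
Compound 2, `COc1ccc(/C=C\c2cc(OC)c(OC)c(OC)c2)cc1OCc1ccc(CN[C@H](C(=O)O)[C@@H](C)O)cc1`, gives in this assay a limit, > 10000 nM.
Compound 3, `COc1ccc(/C=C\c2cc(OC)c(OC)c(OC)c2)cc1OCc1ccc(CNCCO)cc1`, gives 1200 nM in this assay.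

Compound 3 stands lowest of the two numbers shown; its nearest neighbour is compound 1, with a 4.5-fold lower number from compound 1 to compound 3 (0.65 log units; beyond the scatter) separating them. Compound 4, `COc1ccc(/C=C\c2cc(OC)c(OC)c(OC)c2)cc1OCc1ccc(CNC(C)(C)C(=O)O)cc1`, differs from compound 3 in one place: 1-carboxy-1-methylethyl in place of 2-hydroxyethyl on an amine nitrogen. For the measured compounds named here, two measured steps bear on this change. In the step of an at least 8.3-fold lower number from compound 2 to compound 3 (0.92 log units; beyond the scatter) a carboxy-bearing group on the amine nitrogen gave way to 2-hydroxyethyl and the number fell, though the size of that fall rests on a limit (the limit of > 10000 nM in this assay, at which 1 of the 3 values shown sits). In the step of a 4.5-fold lower number from compound 1 to compound 3 (0.65 log units; beyond the scatter) the 2-carboxypiperidin-1-yl group likewise gave way to a group without a carboxy and the number fell. Compound 4 brings a carboxy back onto the amine nitrogen, so a higher number than compound 3 is expected in this assay, and a step of about a 4.6-fold higher number from compound 3 to compound 4 (0.66 log units; beyond the scatter) is estimated. Compound 4 is therefore expected to give about 5500 nM, within a range from 2000 nM to 15000 nM.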

Compound 4, half-maximal inhibitory concentration: > 10000 nM
Compound 4 was reported as a limit; the forecaster's own chance of this, stated with the estimate: 30%; middle value at least 1.8-fold (0.25 log units) from the limit.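

In this assay, for the compounds shown here, the step of an at least 8.3-fold higher number from compound 3 to compound 4 (0.92 log units; beyond the scatter) tests directly what the earlier pairs only suggested: a carboxy-bearing group on the amine nitrogen raises the number even without the 2-carboxypiperidin-1-yl ring or the hydroxyl-bearing chain of compound 2. The step of an at least 1.8-fold higher number from compound 1 to compound 4 (0.26 log units; that floor lies within the scatter) has a floor within the scatter, so compound 4 cannot be set apart from compound 1. The value of compound 4 is a limit, so both steps are floors and the step between compound 2 and compound 4 cannot be read: the limit of > 10000 nM in this assay, at which 2 of the 4 values shown sit.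

The compounds shown leave open whether the carboxylic acid or the two methyl groups of 1-carboxy-1-methylethyl account for the rise. A 2-hydroxy-1,1-dimethylethyl group or a methyl ester on the same amine nitrogen would separate the two.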